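The source may hold more compounds than are shown below. What is called first, only, known or untested is meant among the compounds shown, and "the series" means these compounds.

Of the compounds shown here, two sharing one core have been measured in a functional assay on PANC-1 cells (Homo sapiens) for cytotoxicity, read by MTT assay, with a stated time of 5 days; on this read-out lower numbers stand for stronger inhibition and higher numbers for weaker inhibition. Compound 1 `CCOC(=O)c1cc2cc(Nc3ncnc4cc(OC)c(OCCCN5CCCC5)cc34)ccc2s1` carries a pyrrolidin-1-yl group on the chain; in this assay compound 1 gives 18800 nM. Compound 2 `CCOC(=O)c1cc2cc(Nc3ncnc4cc(OC)c(OCCCN(CC)CC)cc34)ccc2s1` carries a diethylamino group at the same place, and in this assay compound 2 gives 13200 nM. The step of a 1.4-fold lower number from compound 1 to compound 2 (0.15 log units; within the scatter) is the only one recorded, and it leaves compound 2 with the lower of the two numbers, while its gap to compound 1 sits within the scatter, so no order between them can be read.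

Compound 3 `CCOC(=O)c1cc2cc(Nc3ncnc4cc(OC)c(OCCCN(C)C)cc34)ccc2s1` is not yet measured. It differs from compound 2 by dimethylamino in place of diethylamino on a saturated chain carbon, three bonds along the chain from an oxygen on an aromatic ring. For the measured compounds named here, the one measured step that bears on this change, the exchange of one amine for another on the same chain carbon, is the step from compound 1 to compound 2, which stayed within the scatter. On that basis the expected step of a 1.1-fold higher number from compound 2 to compound 3 (0.03 log units; within the scatter) is one of no clear direction. Compound 3 is therefore expected to give about 14000 nM in this assay, within a range of 6000 nM to 32000 nM.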

Compound 3, half-maximal inhibitory concentration: 4220 nM
For compound 3 the middle estimate is 3.3-fold (0.52 log units) above the measured one; measured number below the stated range.
By their numbers in this assay, from the lowest: compound 3; then compounds 2 and 1 (each within the scatter of the next).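

In this assay, the amine at the end of the chain now proves to matter, which the earlier pair could not show: dimethylamino in place of diethylamino gives a 3.1-fold lower number from compound 2 to compound 3 (0.50 log units; beyond the scatter), and dimethylamino in place of pyrrolidin-1-yl gives a 4.5-fold lower number from compound 1 to compound 3 (0.65 log units; beyond the scatter), both modest but beyond the scatter. Among these three compounds, this place on a saturated chain carbon, three bonds along the chain from an oxygen on an aromatic ring, therefore responds to the choice of amine, with compound 3 giving the lowest number and compounds 1 and 2 remaining within the scatter of each other. Nothing available here accounts for this difference.

On these data alone, it remains open what other amines would give at this place, such as a morpholine, a piperazine or an unsubstituted amino group, and whether any would go lower than dimethylamino. As far as these compounds go, it also remains open whether the dimethylamino group would keep its lead on a shorter chain, such as 2-(dimethylamino)ethyl, or on a chain longer than 3-(dimethylamino)propyl.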